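Shortening the chain and adding a hydroxypiperidine

This account rests on a few compounds, and the source may have more. Where it says the series, first, only, none or still open, it means among the compounds named here.

Compound 1, `O=C1c2c[n+]([O-])c3ccccc3c2C(=O)c2[nH]c3ccccc3c21`, gives 320 nM in a functional assay on A549 cells (Homo sapiens) for cytotoxicity, read by MTT assay, with a stated time of 72 h; on this read-out higher numbers stand for weaker inhibition and lower numbers for stronger inhibition.
Compound 2, `O=C1c2c[n+]([O-])c3ccccc3c2C(=O)c2c1c1ccccc1n2CCCCN1CCCCC1`, gives 150 nM in this assay.
Compound 3, `CN(C)CCCCn1c2c(c3ccccc31)C(=O)c1c[n+]([O-])c3ccccc3c1C2=O`, gives 310 nM in this assay.

Compound 3 sits at the second highest of the three numbers; it is indistinguishable from compound 1, and compound 2 lies beyond the scatter below it, as the step of a 2.1-fold higher number from compound 2 to compound 3 (0.32 log units; beyond the scatter) shows. The step of a 1.0-fold lower number from compound 1 to compound 3 (0.01 log units; within the scatter) is flat, whereas a 2.1-fold lower number from compound 1 to compound 2 (0.33 log units; beyond the scatter) is a modest gain.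

Compound 4, `O=C1c2c[n+]([O-])c3ccccc3c2C(=O)c2c1c1ccccc1n2CCCN1CCC(O)CC1`, has not yet been measured in this assay. It differs from compound 3 by 4-hydroxypiperidin-1-yl in place of (dimethylamino)methyl on a saturated chain carbon, three bonds along the chain from an aromatic nitrogen. Within the data shown here, the only measured step that resembles this change is a 2.1-fold higher number from compound 2 to compound 3 (0.32 log units; beyond the scatter), in which a ring amine on the chain gave a modestly lower number than the open dimethylamino group. Among the measured compounds shown here, compound 4 again carries a ring amine, now a 4-hydroxypiperidin-1-yl one, on a chain that is one bond shorter; no measured pair speaks to the hydroxyl or to the chain length. On that basis a modest lowering is expected, a 1.6-fold lower number from compound 3 to compound 4 (0.19 log units; within the scatter), with wide uncertainty. Compound 4 is therefore estimated at 200 nM, within a range of 90 nM to 450 nM.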

Compound 4, half-maximal inhibitory concentration: 350 nM
Estimate against measurement, compound 4: 1.8-fold (0.24 log units) below; low and high end bracket the measured number.
By their numbers in this assay, from the lowest: compound 2; then compounds 3, 1 and 4 (each within the scatter of the next).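

In this assay, replacing the 4-(dimethylamino)butyl chain with 3-(4-hydroxypiperidin-1-yl)propyl leaves the number flat (a 1.1-fold higher number from compound 3 to compound 4 (0.05 log units; within the scatter)), and this chain in place of hydrogen on the aromatic nitrogen also leaves it level with the unsubstituted compound (a 1.1-fold higher number from compound 1 to compound 4 (0.04 log units; within the scatter)). A ring amine on the chain therefore does not by itself bring the modest gain seen for compound 2, which stays clearly apart from the new compound (a 2.3-fold higher number from compound 2 to compound 4 (0.37 log units; beyond the scatter)), while compounds 1, 3 and 4 cannot be told apart. No accompanying measurement bears on this result, and the numbers alone offer no explanation for it.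

From the compounds shown here alone, whether the gap between compound 2 and compound 4 goes with the hydroxyl or with the shorter chain stays open, as the two compounds differ in both; a 4-(4-hydroxypiperidin-1-yl)butyl chain or a 3-(piperidin-1-yl)propyl chain would separate them. Going by these compounds, how other ring amines on the chain, such as morpholine or piperazine, would compare also remains open.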